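Ethyl for methyl on the ring amine: tracheal inhibition

The source may report more compounds than this note shows. Statements on the series, on what has been measured and on what is new or still open speak of the compounds shown alone.

Measured so far:
- compound 1 `CCN1CC[C@@]2(OC)OC(N)=C(C#N)[C@@H](c3ccc(Cl)cc3)[C@@H]2C1`: 14900 nM
- compound 2 `COc1ccc([C@@H]2C(C#N)=C(N)O[C@]3(OC)CCN(C)C[C@@H]23)cc1`: 23100 nM

Two compounds share the core and carry it into a functional assay on trachea (Cavia porcellus); on this read-out higher numbers stand for weaker inhibition and lower numbers for stronger inhibition. Compound 1 gives 14900 nM there. Among the measured compounds shown here, compound 2 gives 23100 nM in this assay, the higher of the two numbers, but its gap to compound 1 lies within the scatter, so the two values cannot be placed in order; no step between them is worked out here, and the pair differs in more than one place.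

Compound 3 `CCN1CC[C@@]2(OC)OC(N)=C(C#N)[C@@H](c3ccc(OC)cc3)[C@@H]2C1` is not yet measured in this assay. It differs from compound 2 by one change, (methyl in place of hydrogen on a saturated chain carbon bound to an amine nitrogen in a ring); read one bond further out, this is methyl to ethyl on the ring amine. Compound 1 already carries that ethyl and shows no number apart from compound 2 beyond the scatter, so the expectation is that the step from compound 2 to compound 3, a 1.2-fold lower number from compound 2 to compound 3 (0.06 log units; within the scatter), stays within the scatter in either direction. Compound 3 is therefore estimated at 20000 nM in this assay, with a range from 8000 nM to 50000 nM.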

Compound 3, half-maximal inhibitory concentration: 25500 nM
Compound 3: middle estimate off by 1.3-fold (0.11 log units), on the low side; the range from low to high includes it.
By their numbers in this assay, from the lowest: compounds 1, 2 and 3 (each within the scatter of the next).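

In this assay, methyl in place of hydrogen on a saturated chain carbon bound to an amine nitrogen in a ring now has a step of its own, read with the aromatic methoxy held fixed: a 1.1-fold higher number from compound 2 to compound 3 (0.04 log units; within the scatter). Compound 3 also links the other two compounds through a second single change, methoxy in place of chloro on an aromatic carbon, read with the ethyl held fixed: a 1.7-fold higher number from compound 1 to compound 3 (0.23 log units; within the scatter). Both changes therefore stay within the scatter here, and no supporting measurement bears on why either step has this size.

Each change is read on a single background only, so neither result can be taken as general for the series. On these data alone, whether a longer chain such as propyl or benzyl at the amine position, or a carboxylic acid or an amine in place of the methoxy on the aromatic carbon, would carry the number beyond the scatter stays open.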